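Nitro in place of bromo: expectation for compound 4

The compounds below may be only part of what the source reports. "The series", "measured", "known", "first", "only" and "open" are said of these compounds alone.

In a functional assay on NCI-H460 cells (Homo sapiens) for antiproliferative activity, read by sulforhodamine B assay, with a stated time of 48 h (a lower number here means a stronger inhibitor, a higher number a weaker inhibitor), compound 1 `O=C(CCCCCCN1C(=O)/C(=N\O)c2ccccc21)NO` gives 890 nM, compound 2 `O=C(CCCCCCN1C(=O)/C(=N\O)c2cc(Cl)ccc21)NO` gives 850 nM and compound 3 `O=C(CCCCCCN1C(=O)/C(=N\O)c2cc(Br)ccc21)NO` gives 970 nM. Compound 3 therefore stands level with the other two, within the scatter of each.

Among the compounds with values here, three measured steps bear on the next change. Chloro in place of hydrogen is a 1.0-fold lower number from compound 1 to compound 2 (0.02 log units; within the scatter). Bromo in place of hydrogen is a 1.1-fold higher number from compound 1 to compound 3 (0.04 log units; within the scatter). Bromo in place of chloro is a 1.1-fold higher number from compound 2 to compound 3 (0.06 log units; within the scatter). None of the three goes beyond the scatter.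

Compound 4 `O=C(CCCCCCN1C(=O)/C(=N\O)c2cc([N+](=O)[O-])ccc21)NO` has not yet been measured. It carries nitro in place of bromo on an aromatic carbon, (nitro in place of bromo on an aromatic carbon). Within the data shown here, no nitro compound has been measured in this set, so the steps above guide the expectation only indirectly, and the range is kept wide.

The expectation rests on compound 3, which at 970 nM shows no separation from compound 1 at 890 nM. No step beyond the scatter is expected in this assay, and no direction is favoured. The estimated step is a 1.1-fold lower number from compound 3 to compound 4 (0.06 log units; within the scatter). For compound 4 the expected value is 850 nM, with an estimated range of 380 nM to 1900 nM.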

Compound 4, half-maximal inhibitory concentration: 7710 nM
Estimate against measurement, compound 4: 9.1-fold (0.96 log units) below; the whole stated range lies below it.
By their numbers in this assay, from the lowest: compounds 2, 1 and 3 (each within the scatter of the next); then compound 4.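

In this assay, this aromatic carbon proves not to be indifferent to what it carries: nitro in place of hydrogen is an 8.7-fold higher number from compound 1 to compound 4 (0.94 log units; beyond the scatter), whereas chloro and bromo on the same carbon stayed within the scatter of hydrogen. Measured from either halogen the step is also beyond the scatter, a 7.9-fold higher number from compound 3 to compound 4 (0.90 log units; beyond the scatter) for nitro in place of bromo and a 9.1-fold higher number from compound 2 to compound 4 (0.96 log units; beyond the scatter) for nitro in place of chloro, so the nitro compound stands apart from the other three, which remain level with one another. Nitro brings three heavy atoms and two hydrogen-bond acceptors where bromo brings one heavy atom and none, but nothing available ties the weaker number to either feature or offers any explanation for it.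

The compounds shown leave open whether the weaker number is peculiar to nitro or extends to other groups on this carbon, such as an amine, a nitrile or a carboxylic acid. They also leave open whether nitro would give the same step on another carbon of the aromatic ring, or alongside a shorter chain.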